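Cyanopyrrolidine in place of cyanoazetidinylmethyl, biphenylmethoxy series

This account rests on a few compounds, and the source may have more. Where it says the series, first, only, none or still open, it means among the compounds named here.

Of the compounds shown here, three have been measured: compound 1 `N#CN1CC(OCc2ccc(-c3ccccc3)cc2)C1`, compound 2 `N#CN1CC(COCc2ccc(-c3ccccc3)cc2)C1` and compound 3 `N#CN1CC(OCc2ccc(Oc3ccccc3)cc2)C1`. In an assay on isolated protein for inhibition of N-acylethanolamine-hydrolyzing acid amidase (Homo sapiens), read by fluorescence, with a stated time of 90 min (a lower number here means a stronger inhibitor, a higher number a weaker inhibitor), compound 1 gives 2.8 nM, compound 2 gives 3.4 nM and compound 3 gives 1.1 nM. Compound 2 holds the highest number of the three; the step of a 1.2-fold higher number from compound 1 to compound 2 (0.08 log units; within the scatter) lies within the scatter, whereas a 2.5-fold lower number from compound 1 to compound 3 (0.41 log units; beyond the scatter) lies beyond it. The unmeasured compound 4, `N#CN1CC[C@H](OCc2ccc(-c3ccccc3)cc2)C1`, differs from compound 2 thus: 1-cyanopyrrolidin-3-yl in place of (1-cyanoazetidin-3-yl)methyl on an oxygen on a saturated carbon. Among the measured compounds shown here, the only measured step touching this part of the molecule is a 1.2-fold higher number from compound 1 to compound 2 (0.08 log units; within the scatter), which stayed within the scatter; the aryl end is untouched. No step beyond the scatter is therefore expected in this assay. For compound 4 the estimate is 3 nM, range 1 nM to 9 nM. The step of a 1.1-fold lower number from compound 2 to compound 4 (0.05 log units; within the scatter) is thus expected to remain within the scatter.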

Compound 4, half-maximal inhibitory concentration: 315 nM
The estimate for compound 4 lay 110-fold (2.02 log units) below the measured number; the whole stated range lies below it.
By their numbers in this assay, from the lowest: compound 3; then compounds 1 and 2 (each within the scatter of the next); then compound 4.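

In this assay, the group on this oxygen proves far less tolerant than the azetidine pair implied: both the step (a 93-fold higher number from compound 2 to compound 4 (1.97 log units; beyond the scatter)) and the step (a 110-fold higher number from compound 1 to compound 4 (2.05 log units; beyond the scatter)) are large. Compared with compound 2, the loss comes with no change in the counted atoms, donors or acceptors, only a five-membered ring in place of a four-membered ring with a different attachment. No supporting data bear on why this loss occurs.

On these data alone, the opposite stereocentre of 1-cyanopyrrolidin-3-yl remains open. So does whether 1-cyanopiperidin-4-yl on this oxygen, or phenoxy in place of phenyl on compound 4, would restore the low numbers.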